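The source may hold more compounds than are shown below. What is called first, only, known or untested is meant among the compounds shown, and "the series" means these compounds.

Within the data shown here, compound 1 `CN1CCN(c2cc(C(F)(F)F)ccc2[C@H]2CCOc3cc(S(=O)(=O)Nc4nccs4)ccc32)CC1` gives 2.1 in a physicochemical assay for lipophilicity (a higher number here means a more lipophilic compound, a lower number a more polar compound), and holds the lowest of the three numbers so far. Compound 3 `Cc1ccc(-c2cc(C(F)(F)F)ccc2[C@H]2CCOc3cc(S(=O)(=O)Nc4ncc(F)cn4)ccc32)cn1` stands at 2.5 and compound 2 `Cc1nc(-c2cc(C(F)(F)F)ccc2[C@H]2CCOc3cc(S(=O)(=O)Nc4ncc(F)cn4)ccc32)co1` at 2.8 on the same measure, both beyond the scatter from compound 1. The change to compound 4 `O=S(=O)(Nc1nccs1)c1ccc2c(c1)OCC[C@@H]2c1ccc(C(F)(F)F)cc1-c1ccc(F)cc1` is 4-fluorophenyl in place of 4-methylpiperazin-1-yl on an aromatic carbon with 4-fluorophenyl in place of 4-methylpiperazin-1-yl on an aromatic carbon, ortho to a large group and meta to a trifluoromethyl group. Among the measured compounds shown here, the one measured step at this place is a number 0.30 log units lower from compound 2 to compound 3 (within the scatter) for 6-methylpyridin-3-yl in place of 2-methyl-1,3-oxazol-4-yl; it exchanges one aromatic group for another. For the measured compounds named here, no measured step removes 4-methylpiperazin-1-yl. Compound 2 and compound 3 also differ from compound 1 in a second place, yet both carry an aromatic group where compound 1 has 4-methylpiperazin-1-yl, and both read higher. A rise in this assay beyond the scatter is therefore expected, with an estimated size of a number 0.90 log units higher from compound 1 to compound 4 (beyond the scatter) for this exchange. For compound 4 the estimate is 3 with an expected range from 2.5 to 3.5 on this measure.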

Compound 4, distribution coefficient: 4.5
Compound 4: the middle estimate sits 1.50 log units below what was measured, and the stated range ends below it.
By their numbers in this assay, from the lowest: compound 1; then compounds 3 and 2 (each within the scatter of the next); then compound 4.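

In this assay, among these compounds, the exchange at this aromatic carbon, ortho to a large group and meta to a trifluoromethyl group, gives a number 2.40 log units higher from compound 1 to compound 4 (beyond the scatter), the first direct reading of the loss of 4-methylpiperazin-1-yl with the rest of the molecule unchanged. Among the compounds shown here, until now the only step at this position was an exchange of one aromatic group for another, a number 0.30 log units lower from compound 2 to compound 3 (within the scatter), so this result shows that the choice of group here can carry a large change. No evidence on hand bears on the size of this step.

Open, from the compounds shown here alone, is how much of the step belongs to the departure of 4-methylpiperazin-1-yl and how much to the arrival of 4-fluorophenyl. Also open, going by these compounds, is how an unsubstituted phenyl, a morpholine or an open-chain amine would read at this position on the core of compound 1.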